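The compounds below may be only part of what the source reports. "The series", "measured", "known", "first", "only" and "open" are said of these compounds alone.

Compound 1 (`O=C(CCCCOc1cccc(-c2nnc(-c3ccccc3)s2)c1)NO`) : 490 nM
Compound 2 (`O=C(CCCCCCOc1cccc(-c2nnc(-c3ccccc3)s2)c1)NO`) : 710 nM

Among the measured compounds shown here, in a functional assay on MOLT-4 cells (Homo sapiens) for antiproliferative activity, read by CCK-8 assay, with a stated time of 48 h (a higher number here means a weaker inhibitor, a lower number a stronger inhibitor), compound 2 gives 710 nM and lies within the scatter of compound 1, the only other measured compound. Compound 3 (`O=C(CCCCCCOc1cccc(-c2nnc(-c3ccccc3Cl)s2)c1)NO`) differs from compound 2 by a single change: chloro in place of hydrogen on an aromatic carbon, ortho to a large group (chloro in place of hydrogen on an aromatic carbon). For the measured compounds named here, the one measured step is a 1.4-fold higher number from compound 1 to compound 2 (0.16 log units; within the scatter) and it lies in the chain, not on the aromatic ring that changes here. Going by the values given here, no measured compound carries chloro, so the data give no direct guide to this change. No step beyond the scatter is therefore expected in this assay and no direction can be favoured. The step expected is a 1.1-fold lower number from compound 2 to compound 3 (0.04 log units; within the scatter) as an estimate only. Compound 3 is estimated at 650 nM with an expected range from 230 nM to 1800 nM in this wide estimate.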

Compound 3, half-maximal inhibitory concentration: 2400 nM
The estimate for compound 3 lay 3.7-fold (0.57 log units) below the measured number, outside the stated range (above it).
By their numbers in this assay, from the lowest: compounds 1 and 2 (each within the scatter of the next); then compound 3.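

In this assay, among the compounds shown here, going from phenyl to 2-chlorophenyl gives a 3.4-fold higher number from compound 2 to compound 3 (0.53 log units; beyond the scatter), and this single added chlorine on the terminal aromatic ring is the first change to move the number beyond the scatter. The earlier step, a 1.4-fold higher number from compound 1 to compound 2 (0.16 log units; within the scatter), lay in the chain and stayed within the scatter, so the aromatic carbon ortho to a large group proves more sensitive to this change than the chain was to its change. Nothing available accounts for the rise.

The compounds shown leave open whether the higher number belongs to chloro itself or to any group at this carbon, a question that fluoro or methyl at the same place would address. They also leave open whether chloro on another carbon of that ring, or on the shorter chain of compound 1, would give a similar step.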